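A few compounds are considered here, and "the series" means these few. Any claim that something is new, unique, unknown or untested is made for them only; others in the source may bear on it.

Four compounds built on the same core were compared for pain relief in mice. Compound 1 `C[C@@H](O)[C@H](NC(=O)CN(c1nc(Cl)nc2[nH]cnc12)C1CC1)C(=O)OCc1ccccc1` carries a benzyl ester and a 1-hydroxyethyl group on the saturated chain carbon bound to an amide-type nitrogen and a carbonyl carbon. In a functional assay on the whole organism (Tail, strain ICR) with Mus musculus as the target, in the tail flick test, with a stated time of 150 min, at a dose of 25 umol/kg by the oral route (a lower number here means a weaker effect, a higher number a stronger effect of the compound at the dose given), compound 1 gives 12.8%. Compound 2 `NCCCC[C@H](NC(=O)CN(c1nc(Cl)nc2[nH]cnc12)C1CC1)C(=O)OCc1ccccc1` keeps the benzyl ester but carries a 4-aminobutyl group in that place; in this assay compound 2 gives 9.88%. Compound 3 `C[C@@H](O)[C@H](NC(=O)CN(c1nc(Cl)nc2[nH]cnc12)C1CC1)C(=O)O` is the free acid of compound 1; in this assay compound 3 gives 24%. Compound 4 `NCCCC[C@H](NC(=O)CN(c1nc(Cl)nc2[nH]cnc12)C1CC1)C(=O)O` is the free acid of compound 2 and has not yet been tested.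

The change from compound 1 to compound 2 is described as 4-aminobutyl in place of 1-hydroxyethyl on a saturated chain carbon bound to an amide-type nitrogen and a carbonyl carbon, and it produced a step of a number 2.9 percentage points lower from compound 1 to compound 2 (within the scatter). The two cores differ by hydrogen in place of benzyl on an oxygen next to a carbonyl group, a step of a number 11.2 percentage points higher from compound 1 to compound 3 (beyond the scatter). The change from compound 3 to compound 4 is 4-aminobutyl in place of 1-hydroxyethyl on a saturated chain carbon bound to an amide-type nitrogen and a carbonyl carbon, which is the same change as that between compound 1 and compound 2, made at the same place.

Because the earlier step was a number 2.9 percentage points lower from compound 1 to compound 2 (within the scatter), the step from compound 3 to compound 4 is expected to be similarly small, about a number 3 percentage points lower from compound 3 to compound 4 (within the scatter). Compound 4 is therefore estimated at 21% in this assay, expected to fall between 10% and 32%.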

Compound 4, a percentage reported as activity, at one dose (the size of the read-out at that dose, not a potency): 11.6%
The estimate for compound 4 lay 9.4 percentage points above the measured number; low and high end bracket the measured number.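

The swap of 1-hydroxyethyl for 4-aminobutyl in this assay gave a step of a number 12.4 percentage points lower from compound 3 to compound 4 (beyond the scatter), larger on paper than the same swap on the benzyl ester core, yet the two steps cannot be told apart: the same change on two cores in this assay, a number 2.9 percentage points lower (within the scatter) from compound 1 to compound 2 and a number 12.4 percentage points lower (beyond the scatter) from compound 3 to compound 4, 9.5 percentage points apart, within the scatter of two such steps. Replacing the benzyl on the ester oxygen with hydrogen gave a step of a number 1.7 percentage points higher from compound 2 to compound 4 (within the scatter), and this change likewise cannot be separated from its earlier counterpart: the same change on two cores in this assay, a number 11.2 percentage points higher (beyond the scatter) from compound 1 to compound 3 and a number 1.7 percentage points higher (within the scatter) from compound 2 to compound 4, 9.5 percentage points apart, within the scatter of two such steps. For the compounds shown here, the results therefore fit both changes carrying over from one core to the other, but with only one pair of steps for each change, they neither show that a step keeps its size on a new core nor that its size depends on the core.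

The compounds shown leave open what a plain methyl group or a chain ending in a carboxylic acid would give on the saturated chain carbon bound to an amide-type nitrogen and a carbonyl carbon, and what an ethyl ester would give in place of the benzyl ester. They also leave open whether these steps would hold at other doses or times, since each number is a single read-out at one dose and one time.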